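Two weak antiproliferative readings and a third analogue

The compounds below may be only part of what the source reports. "The series", "measured", "known", "first", "only" and "open" are said of these compounds alone.

Measured compounds in a functional assay on SW-620 cells (Homo sapiens) for antiproliferative activity, read by MTT assay, with a stated time of 72 h; on this read-out higher numbers stand for weaker inhibition and lower numbers for stronger inhibition:
compound 1, `COc1ccc(-c2cn(C/C=C3\OC(=O)C(OCc4ccccc4)=C3OCc3ccccc3)nn2)cc1`: > 100000 nM, a limit of the assay and not a number
compound 2, `O=C1O[C@H]([C@@H](O)Cn2cc(CNS(=O)(=O)c3ccc(Cl)cc3F)nn2)C(OCc2ccccc2)=C1OCc1ccccc1`: 42400 nM

The reading of compound 1 sits at the limit of > 100000 nM in this assay, at which 1 of the 2 values shown sits, and is a limit, not a number. Compound 2 carries the only number shown. Among the compounds with values here, no pair of measured compounds differs in a single place, so the size of any one change cannot be read from the set itself.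

Compound 3, `O=C1O[C@H]([C@@H](O)Cn2cc(CCCCl)nn2)C(OCc2ccccc2)=C1OCc1ccccc1`, differs from compound 2 by 2-chloroethyl in place of ((4-chloro-2-fluorophenyl)sulfonyl)amino on a saturated chain carbon bound to an aromatic carbon. Within the data shown here, no measured step bears on this change. In this assay the expected step is a 1.4-fold higher number from compound 2 to compound 3 (0.15 log units; within the scatter), of moderate size toward weaker inhibition or none beyond the scatter. Compound 3 is estimated at 60000 nM, with a range from 20000 nM to 150000 nM. A limit reading rather than a number is a real possibility for compound 3.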

Compound 3, half-maximal inhibitory concentration: 68500 nM
Estimate against measurement, compound 3: 1.1-fold (0.06 log units) below; the measured number falls inside the stated range.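

In this assay, the set now holds its first single-place step: a 1.6-fold higher number from compound 2 to compound 3 (0.21 log units; within the scatter). At this position, on a saturated chain carbon bound to an aromatic carbon, the readings therefore do not separate ((4-chloro-2-fluorophenyl)sulfonyl)amino, with its six-membered aromatic ring and hydrogen-bond donor, from the much smaller 2-chloroethyl, which has no ring and no donor. Compound 1 remains the only compound with a limit reading, which is a limit and not a number: the limit of > 100000 nM in this assay, at which 1 of the 3 values shown sits.

From the compounds shown here alone, whether an amine or a carboxylic acid at this position would give a reading clear of the scatter from compound 2 stays open. Also open, going by these compounds, is whether a plain ethyl or a longer chain ending in chlorine would read like compound 3.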